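The compounds below may be only part of what the source reports. "The series", "measured", "known", "first", "only" and "open" are said of these compounds alone.

For the measured compounds named here, compound 2 `Clc1cnccc1-c1cc(-c2cnn(C3CCNCC3)c2)on1` gives 200 nM in an assay on isolated protein for positive allosteric modulation of Neuronal acetylcholine receptor; alpha4/beta2 (Homo sapiens) (a higher number here means that more compound is needed for the effect, a lower number that less compound is needed), the lowest of the two numbers measured so far; its nearest neighbour is compound 1 `Fc1ccc(Cl)c(-c2cc(-c3cnn(C4CCNCC4)c3)on2)c1`, which in this assay gives 270 nM, and the step of a 1.4-fold lower number from compound 1 to compound 2 (0.13 log units; within the scatter) stays within the scatter. Compound 3 `Cc1cc(-c2cnn(C3CCNCC3)c2)on1` differs from compound 2 by methyl in place of 3-chloropyridin-4-yl on an aromatic carbon. Going by the values given here, only the swap from compound 1 to compound 2 is on record, and it exchanged one aromatic ring for another, so no measured step bears on dropping the ring altogether. The expectation for compound 3 in this assay is a larger number, roughly a 7.5-fold higher number from compound 2 to compound 3 (0.88 log units; beyond the scatter), with wide uncertainty. Compound 3 is estimated at 1500 nM, within 400 nM to 6000 nM.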

Compound 3, half-maximal effective concentration: 1300 nM
For compound 3 the middle estimate is 1.2-fold (0.06 log units) above the measured one, within the range that was stated.
By their numbers in this assay, from the lowest: compounds 2 and 1 (each within the scatter of the next); then compound 3.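

In this assay, methyl in place of the aromatic ring on this carbon, next to the ring nitrogen, gives a 6.5-fold higher number from compound 2 to compound 3 (0.81 log units; beyond the scatter) and a 4.8-fold higher number from compound 1 to compound 3 (0.68 log units; beyond the scatter), so this position responds to losing the ring, whereas exchanging one aromatic ring for another did not move the number beyond the scatter. Both steps are modest, and compound 3 still gives a measured number with methyl alone. No measurement available bears on the reason for these steps.

Going by these compounds, whether the size of the group or the ring itself matters remains open. Ethyl, cyclopropyl or unsubstituted phenyl at this position could separate the two.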